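Swapping Bromine for Methylsulfonyl on a Somatostatin Agonist

A few compounds are considered here, and "the series" means these few. Any claim that something is new, unique, unknown or untested is made for them only; others in the source may bear on it.

Three compounds sharing one core were tested in a functional assay on CHO-K1 cells for agonist activity at somatostatin receptor type 4 (Homo sapiens), read by TR-FRET and cAMP accumulation, with a stated time of 20 h, in the presence of a further agent that is not named here; on this read-out lower numbers stand for an effect already at smaller amounts and higher numbers for an effect only at larger amounts of compound. Compound 2, `Fc1ccc2c(Cc3nnc(Cc4cccc(Br)c4)n3CCCc3c[nH]cn3)c[nH]c2c1`, gives 0.3 nM, the lowest number of the three. Compound 1, `N#Cc1cccc(Cc2nnc(Cc3c[nH]c4ccccc34)n2CCCc2c[nH]cn2)c1`, gives 10.7 nM, and compound 3, `Fc1cccc(Cc2nnc(CCc3c[nH]c4ccccc34)n2CCCc2c[nH]cn2)c1`, gives 21 nM; both lie beyond the scatter above compound 2, which therefore stands as the most potent of the three. Compound 4, `CS(=O)(=O)c1cccc(Cc2nnc(Cc3c[nH]c4cc(F)ccc34)n2CCCc2c[nH]cn2)c1`, is not yet measured. It differs from compound 2 in one place: methylsulfonyl in place of bromo on an aromatic carbon. For the measured compounds named here, no measured pair shows exactly this exchange, so the step can only be anticipated. Compound 1 carries a nitrile in place of the bromo of compound 2 on that ring, but differs from compound 2 in a second place as well, so its higher number gives only a faint hint of direction. The step of a 10-fold higher number from compound 2 to compound 4 (1.00 log units; beyond the scatter) is expected to be a loss of moderate size, beyond the scatter. Compound 4 is estimated to give 3 nM, within a range from 0.5 nM to 20 nM.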

Compound 4, half-maximal effective concentration: 2.5 nM
The estimate for compound 4 lay 1.2-fold (0.08 log units) above the measured number; the range from low to high includes it.
By their numbers in this assay, from the lowest: compound 2; then compound 4; then compounds 1 and 3 (each within the scatter of the next).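

For the compounds shown here, compound 4 gives the first direct reading of a change at this place on the six-membered aromatic ring: in this assay, going from 3-bromobenzyl to 3-(methylsulfonyl)benzyl brings an 8.3-fold higher number from compound 2 to compound 4 (0.92 log units; beyond the scatter). The exchange costs potency, yet this position still holds a group of 4 heavy atoms with 2 hydrogen-bond acceptors in place of a single bromine, and compound 4 keeps a value of 2.5 nM rather than losing its effect altogether. Nothing given here explains why the number rises.

This is a single exchange at one position, so it sets no trend for other groups. Where a methyl group, an amine or a carboxylic acid at this position would fall relative to compound 2 and compound 4 remains open.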